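A few compounds are considered here, and "the series" means these few. Any claim that something is new, unique, unknown or untested is made for them only; others in the source may bear on it.

Compound 1 `O=C(Nc1ccc(Cl)c(Cl)c1)c1nc[nH]c1C(=O)NCc1ccc(Cl)cc1` gives 16200 nM in a functional assay on HL-60 cells (Homo sapiens), with a stated time of 2 days; on this read-out lower numbers stand for stronger inhibition and higher numbers for weaker inhibition. Compound 2 `COC(=O)[C@@H](C)NC(=O)c1[nH]cnc1C(=O)Nc1ccc(Cl)c(Cl)c1` reaches only a limit of the assay in this assay, > 62500 nM. The step of an at least 3.8-fold higher number from compound 1 to compound 2 (0.58 log units; beyond the scatter) therefore rests on (the limit of > 62500 nM in this assay, at which 1 of the 2 values shown sits), and compound 2 stands at the weak end of the two values shown. Compound 3 `C[C@H](NC(=O)c1[nH]cnc1C(=O)Nc1ccc(Cl)c(Cl)c1)C(=O)OC(C)(C)C` differs from compound 2 by 1-(tert-butoxycarbonyl)ethyl in place of 1-(methoxycarbonyl)ethyl on an amide-type nitrogen. Among the compounds with values here, no measured step touches this change: the one measured step altered a different part of the nitrogen substituent, so its size gives no direct guidance here. Compound 3 is expected to stay near the limit, with an estimated 80000 nM (range 20000 nM to 300000 nM), an expected step that the limit leaves unreadable from compound 2 to compound 3.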

Compound 3, half-maximal inhibitory concentration: 4900 nM
Beside the measured number, compound 3's estimate is 16-fold (1.21 log units) above it; measured number below the stated range.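

On this amide-type nitrogen, the ester part of the substituent decides the read-out: 1-(tert-butoxycarbonyl)ethyl in place of 1-(methoxycarbonyl)ethyl gives an at least 12-fold lower number from compound 2 to compound 3 (1.10 log units; beyond the scatter). The size of this step has only a lower bound, as compound 2 stands at a limit of this assay: the limit of > 62500 nM in this assay, at which 1 of the 3 values shown sits. The same group also gives a 3.3-fold lower number from compound 1 to compound 3 (0.52 log units; beyond the scatter), so among the compounds shown, a substituent with no ring on this nitrogen can outperform 4-chlorobenzyl.

Still open, from the compounds shown here alone, is how an ethyl or isopropyl ester would compare with compound 2 and compound 3. Also open, going by these compounds, is whether a carboxylic acid or a primary amide in place of the ester would keep the activity of compound 3.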